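Carbamate to urea exchange on the sulfamide-bearing chain

A few compounds are considered here, and "the series" means these few. Any claim that something is new, unique, unknown or untested is made for them only; others in the source may bear on it.

Measured compounds in an assay for inhibition of protein deacetylase HDAC6 (Homo sapiens); on this read-out lower numbers stand for stronger inhibition and higher numbers for weaker inhibition:
compound 1 `NS(=O)(=O)NCCCC[C@H](NC(=O)OCc1ccc(Cl)cc1)C(=O)Nc1nc(-c2ccccc2)cs1`, 530 nM
compound 2 `NS(=O)(=O)NCCCC[C@H](NC(=O)OCc1cccnc1)C(=O)Nc1nc(-c2ccccc2)cs1`, 600 nM
compound 3 `CCOC(=O)N[C@@H](CCCCNS(N)(=O)=O)C(=O)Nc1nc(-c2ccccc2)cs1`, 200 nM

Compound 3 stands with the lowest number of the three, set apart from compound 1 by a 2.7-fold lower number from compound 1 to compound 3 (0.42 log units; beyond the scatter) and from compound 2 by a 3.0-fold lower number from compound 2 to compound 3 (0.48 log units; beyond the scatter), while compound 1 and compound 2 sit within the scatter of each other, a 1.1-fold higher number from compound 1 to compound 2 (0.05 log units; within the scatter). Compound 4 `NS(=O)(=O)NCCCC[C@H](NC(=O)NCc1ccc(F)cc1)C(=O)Nc1nc(-c2ccccc2)cs1` differs from compound 3 by (4-fluorobenzyl)amino in place of ethoxy on a carbonyl carbon. The measured steps bear on this only in part: both replace an aromatic ring with methyl on the chain carbon bound to oxygen, and in each case the number was higher with the ring present. Among the compounds with values here, no measured step covers the change on the carbonyl carbon itself. A modest rise is therefore expected, a 2.3-fold higher number from compound 3 to compound 4 (0.35 log units; beyond the scatter). In this assay compound 4 is estimated at 450 nM, range 180 nM to 1100 nM.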

Compound 4, half-maximal inhibitory concentration: 370 nM
Compound 4: middle estimate off by 1.2-fold (0.09 log units), on the high side; the measured number falls inside the stated range.
By their numbers in this assay, from the lowest: compounds 3, 4, 1 and 2 (each within the scatter of the next, the first and the last beyond it).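

In this assay, (4-fluorobenzyl)amino in place of ethoxy on the carbonyl carbon gives a 1.9-fold higher number from compound 3 to compound 4 (0.27 log units; within the scatter). Against the ring-bearing carbamates the exchange reads a 1.6-fold lower number from compound 2 to compound 4 (0.21 log units; within the scatter) and a 1.4-fold lower number from compound 1 to compound 4 (0.16 log units; within the scatter), so compound 4 cannot be separated from any of the three, although compound 3 stands apart from compound 1 and compound 2. No evidence on hand accounts for this result.

Open, going by these compounds, is whether ethylamino, the ring-free counterpart of ethoxy, would stay within the scatter of compound 3. Compound 4 brings in the nitrogen and the ring together, so their separate contributions remain unresolved.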